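A few compounds are considered here, and "the series" means these few. Any claim that something is new, unique, unknown or untested is made for them only; others in the source may bear on it.

Compound 1, `Cc1cn([C@@H]2O[C@H](CO[Si](C)(C)C(C)(C)C)[C@@]3(OS(=O)(=O)C=C3NC(=O)Nc3ccccc3)[C@H]2O[Si](C)(C)C(C)(C)C)c(=O)n(C)c1=O`, gives 1400 nM in an ADME assay on HEL cells (Homo sapiens) for cytotoxicity, with a stated time of 3 days; a lower number here means that less compound is tolerated, a higher number that more compound is tolerated. Compound 2, `CCNC(=O)NC1=CS(=O)(=O)O[C@@]12[C@@H](CO[Si](C)(C)C(C)(C)C)O[C@@H](n1cc(C)c(=O)n(C)c1=O)[C@@H]2O[Si](C)(C)C(C)(C)C`, differs from it only on the amide-type nitrogen. In this assay compound 2 reaches a limit of the assay, >= 3200 nM. Among the measured compounds shown here, the single measured step, an at least 2.2-fold higher number from compound 1 to compound 2 (0.35 log units; beyond the scatter), thus runs into the ceiling of the assay, where (the limit of >= 3200 nM in this assay, at which 1 of the 2 values shown sits). Compound 3, `CCOC(=O)NC(=O)NC1=CS(=O)(=O)O[C@@]12[C@@H](CO[Si](C)(C)C(C)(C)C)O[C@@H](n1cc(C)c(=O)n(C)c1=O)[C@@H]2O[Si](C)(C)C(C)(C)C`, carries a further change at the same nitrogen: ethoxycarbonyl in place of ethyl on an amide-type nitrogen. For the measured compounds named here, the one measured step concerns a different exchange at that nitrogen and gives no direct guide to an ethoxycarbonyl, so it offers only the observation that compound 2 already sits at the limit. The expected step is therefore a step that the limit leaves unreadable from compound 2 to compound 3, none beyond the scatter, with a good chance that only a limit is again reported. Compound 3 is estimated at 4000 nM, in a range from 1800 nM to 10000 nM.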

Compound 3, minimum cytotoxic concentration: 10000 nM
Compound 3: the middle estimate sits 2.5-fold (0.40 log units) below what was measured; the measured number falls inside the stated range.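

In this assay, among the compounds shown here, compound 3 gives the first number on the high side of the series that is not a limit, so the change at this amide-type nitrogen can now be sized against phenyl: a 7.1-fold higher number from compound 1 to compound 3 (0.85 log units; beyond the scatter). Phenyl therefore carries the lowest number of the three groups at this nitrogen, as ethyl also gave an at least 2.2-fold higher number from compound 1 to compound 2 (0.35 log units; beyond the scatter). The exchange of ethyl for ethoxycarbonyl itself cannot be read, because compound 2 gives only a limit of the assay: the limit of >= 3200 nM in this assay, at which 1 of the 3 values shown sits.

Where compound 2 truly lies relative to compound 3 therefore stays open. Also open, going by these compounds, is whether a longer chain such as butyl, or a methoxycarbonyl or benzyl group on this nitrogen, would give a number as high as ethoxycarbonyl does.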